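This account rests on a few compounds, and the source may have more. Where it says the series, first, only, none or still open, it means among the compounds named here.

Measured compounds:
- compound 1 `CC(C)(C)NC(=O)c1cc(-c2ccc(Cl)cc2Cl)n[nH]1` gives 398 nM
- compound 2 `CN1CCN(C(=O)c2cc(-c3ccc(Cl)cc3Cl)n[nH]2)CC1` gives 828 nM

Both were tested in an assay on isolated protein for inhibition of alkaline phosphatase, tissue-nonspecific isozyme (Homo sapiens); a lower number here means a stronger inhibitor, a higher number a weaker inhibitor. Compound 2 stands highest of the two numbers; its nearest neighbour is compound 1, and the step of a 2.1-fold higher number from compound 1 to compound 2 (0.32 log units; beyond the scatter) is a modest change beyond the scatter. Compound 3 `O=C(c1cc(-c2ccc(Cl)cc2Cl)n[nH]1)N1CCCCCC1` differs from compound 2 by azepan-1-yl in place of 4-methylpiperazin-1-yl on a carbonyl carbon. Within the data shown here, only one measured step bears on a change at this carbonyl carbon, the step from compound 1 to compound 2, and it was modest in size. That step exchanged an open-chain amine for a ring; the present step exchanges one ring for another, so the data give little direct guidance. Compound 3 is therefore expected to land near compound 2, with the step of a 1.5-fold lower number from compound 2 to compound 3 (0.18 log units; within the scatter) estimated to stay within or just beyond the scatter. The estimate for compound 3 in this assay is 550 nM, with a range from 200 nM to 1500 nM.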

Compound 3, half-maximal inhibitory concentration: 1450 nM
Beside the measured number, compound 3's estimate is 2.6-fold (0.42 log units) below it, and the stated range covers the measured number.
By their numbers in this assay, from the lowest: compound 1; then compounds 2 and 3 (each within the scatter of the next).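

In this assay, azepan-1-yl in place of 4-methylpiperazin-1-yl on the carbonyl carbon gives a step within the scatter (a 1.8-fold higher number from compound 2 to compound 3 (0.24 log units; within the scatter)), so these two rings are not told apart here, although they differ in ring size and in hetero atom count. Azepan-1-yl in place of (tert-butyl)amino gives a larger step, beyond the scatter (a 3.6-fold higher number from compound 1 to compound 3 (0.56 log units; beyond the scatter)), which leaves compound 1 with the lowest number of the three, its steps to both ring amides being beyond the scatter. Nothing available here explains these steps.

On these data alone, it remains open whether a smaller ring such as pyrrolidin-1-yl or morpholin-4-yl on this carbonyl carbon would fall with compound 2 and compound 3. As far as these compounds go, it is equally open whether a smaller open-chain amine, such as isopropylamino or cyclopropylamino, would fall with compound 1.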